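This account rests on a few compounds, and the source may have more. Where it says the series, first, only, none or still open, it means among the compounds named here.

Within the data shown here, compound 1 `Cc1cc(-c2nc3sc(C)cn3c2/C=N/NC(=N)N)c(C)s1` is one of two compounds measured in a functional assay on cells (Cancer cell lines, Homo sapiens) for inhibition (a higher number here means a weaker inhibitor of growth, a lower number a stronger inhibitor of growth), where compound 1 gives 4470 nM, the lower of the two numbers. Compound 2 `Cc1cn2c(/C=N/Nc3ccccn3)c(-c3ccc(Cl)c([N+](=O)[O-])c3)nc2s1` gives 13800 nM in this assay, a gap beyond the usual scatter. Compound 3 `Cc1cn2c(/C=N/NC(=N)N)c(-c3ccsc3)nc2s1` has not yet been measured; it differs from compound 1 in one place: thiophen-3-yl in place of 2,5-dimethylthiophen-3-yl on an aromatic carbon. Among the measured compounds shown here, no step between measured compounds covers such a change, so only a small shift is expected, leaning toward a weaker inhibitor, as an estimated step of a 1.5-fold higher number from compound 1 to compound 3 (0.16 log units; within the scatter). Compound 3 is therefore expected to give 6500 nM in this assay, within a range from 2500 nM to 17000 nM.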

Compound 3, concentration for 50% growth inhibition: 7760 nM
Beside the measured number, compound 3's estimate is 1.2-fold (0.08 log units) below it; the range from low to high includes it.
By their numbers in this assay, from the lowest: compounds 1, 3 and 2 (each within the scatter of the next, the first and the last beyond it).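

In this assay, thiophen-3-yl in place of 2,5-dimethylthiophen-3-yl gives a 1.7-fold higher number from compound 1 to compound 3 (0.24 log units; within the scatter). At this aromatic carbon of the shared core, the assay therefore cannot separate the ring with its methyl groups from the bare ring, so these methyl groups are not needed to keep growth inhibition at this level. Nothing measured here points to a cause for this result. Going by these compounds, whether a carboxylic acid or an amine on this ring, or a longer alkyl chain in place of the methyl groups, would move the number beyond the scatter remains open.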